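The source may hold more compounds than are shown below. What is called first, only, known or untested is meant among the compounds shown, and "the series" means these compounds.

Measured so far:
- Compound 1, `N#C[C@@H]1CCCN1C(=O)[C@@H]1C[C@H](C(=O)N2CCCCC2)CN1`: 84%
- Compound 2, `N#C[C@@H]1CCCN1C(=O)[C@@H]1C[C@H](C(N)=O)CN1`: 47%

In an assay on the whole organism (plasma, strain Sprague-Dawley) for inhibition of Dipeptidyl peptidase 4 (Rattus norvegicus), with a stated time of 6 h, at a dose of 1 mg/kg by the oral route (a higher number here means more inhibition at the dose given (going by the name of the read-out), a lower number less inhibition), compound 1 gives 84%, while compound 2 gives 47%. Among the measured compounds shown here, compound 2 thus stands lowest of the two numbers; the only measured step, a number 37 percentage points lower from compound 1 to compound 2 (beyond the scatter), shows that replacing the piperidin-1-yl on the carbonyl carbon with an amino group cost a large part of the effect.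

Compound 3, `CNC(=O)[C@@H]1CN[C@H](C(=O)N2CCC[C@H]2C#N)C1`, differs from compound 2 by methyl in place of hydrogen on an amide-type nitrogen. For the measured compounds named here, no measured step covers exactly this change. Going by the values given here, the step that bears on it is the one from compound 1 to compound 2, which was large, and the methyl on the amide nitrogen restores part of the carbon that the piperidin-1-yl had carried. A gain of moderate size is therefore expected, a number 13 percentage points higher from compound 2 to compound 3 (beyond the scatter), though it could fall within the scatter. Compound 3 is expected to give about 60%, with a likely range from 42% to 78%.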

Compound 3, a percentage reported as inhibition, in the whole organism at one dose (the size of the read-out at that dose, not a potency): 75%
Compound 3: the middle estimate sits 15 percentage points below what was measured, and the stated range covers the measured number.
By their numbers in this assay, from the lowest: compound 2; then compounds 3 and 1 (each within the scatter of the next).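

In this assay, methyl in place of hydrogen on the amide-type nitrogen gives a number 28 percentage points higher from compound 2 to compound 3 (beyond the scatter), so a single added carbon at this position is enough to move the read-out. The step of a number 9 percentage points lower from compound 1 to compound 3 (within the scatter) means that methylamino and piperidin-1-yl on the carbonyl carbon cannot be told apart here, so the whole piperidin-1-yl group is not required to reach the level of compound 1. Nothing shown gives a reason for this gain.

On these data alone, it remains open whether a longer chain on that nitrogen, such as ethyl or propyl, would hold this level or change it. As far as these compounds go, a second methyl on the same nitrogen, which would give dimethylamino, is equally open, as is a smaller ring such as pyrrolidin-1-yl.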